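The compounds below may be only part of what the source reports. "The series", "measured", "known", "first", "only" and "open" are said of these compounds alone.

In a functional assay on NALM-6 cells (Homo sapiens) for cytotoxicity, with a stated time of 72 h (on this read-out lower numbers stand for an effect already at smaller amounts and higher numbers for an effect only at larger amounts of compound), the compounds measured so far:

- Compound 1 `C=C[C@@](C)(/C=C/c1ccc(OC)cc1)CCC=C(C)C`: > 43400 nM
- Compound 2 `C=C[C@@](C)(/C=C/c1ccc(OCc2ccccc2)cc1)CCC=C(C)C`: > 43400 nM
- Compound 3 `C=C[C@@](C)(/C=C/c1ccc(OS(=O)(=O)C(F)(F)F)cc1)CCC=C(C)C`: > 43400 nM

Each of these entries is a limit and not a number. The position of compound 3 is therefore shared with the other two: the limit of > 43400 nM in this assay, at which 3 of the 3 values shown sit.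

Compound 4 `C=C[C@@](C)(/C=C/c1ccc(Nc2ccc(OC)cc2)cc1)CCC=C(C)C` carries (4-methoxyphenyl)amino in place of ((trifluoromethyl)sulfonyl)oxy on an aromatic carbon, para to a large group: (4-methoxyphenyl)amino in place of ((trifluoromethyl)sulfonyl)oxy on an aromatic carbon.

Among the compounds with values here, three measured steps bear on this change, all of them exchanges on the same oxygen-bearing side of the molecule: a step that the two limits leave unreadable from compound 1 to compound 2, a step that the two limits leave unreadable from compound 1 to compound 3 and a step that the two limits leave unreadable from compound 2 to compound 3. Within the data shown here, none of them offers a size to carry over, so the data predict no particular step in this assay. The entering group does differ from all three measured ones, which leaves some room for movement towards lower numbers.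

The expected change is modest: an at least 1.4-fold lower number from compound 3 to compound 4 (0.16 log units; that floor lies within the scatter). A reported limit again is also quite possible. The estimate for compound 4 is 30000 nM, with an expected range from 8000 nM to 60000 nM.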

Compound 4, half-maximal effective concentration: > 43400 nM
Compound 4: only a limit was reported; the forecaster's own chance of this, stated with the estimate: 55%; middle value at least 1.4-fold (0.16 log units) away from the limit.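

Compound 4 is again reported only as a limit in this assay, so no step from compound 1, compound 2 or compound 3 to compound 4 can be read, and all four share one position: the limit of > 43400 nM in this assay, at which 4 of the 4 values shown sit.

The compounds shown leave open whether exchanging the group on this aromatic carbon changes the read-out at all, and by how much.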